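Methylation of the Pyrrole Nitrogen in a Cytotoxicity Series

The source may hold more compounds than are shown below. What is called first, only, known or untested is meant among the compounds shown, and "the series" means these compounds.

Of the compounds shown here, three sharing one core have been measured in an ADME assay on Vero cells (Chlorocebus sabaeus) for cytotoxicity, read by MTT assay, with a stated time of 72 h; a lower number here means a stronger inhibitor, a higher number a weaker inhibitor. Compound 1 `COc1ccc(NC(=S)NNC(=O)c2cc([N+](=O)[O-])c[nH]2)cc1` gives 331000 nM. Compound 2 `O=C(NCc1ccco1)NNC(=O)c1cc([N+](=O)[O-])c[nH]1` gives 443000 nM, and compound 3 `O=C(NNC(=S)Nc1ccc([N+](=O)[O-])cc1)c1cc([N+](=O)[O-])c[nH]1` gives 529000 nM. Compound 1 carries the smallest of the three numbers, yet its gap to compound 2 and its gap to compound 3 both lie within the scatter of repeated measurements, so the three cannot be told apart. For the measured compounds named here, the single step that joins two measured compounds, a 1.6-fold higher number from compound 1 to compound 3 (0.20 log units; within the scatter), is likewise within the scatter.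

Compound 4 `COc1ccc(NC(=S)NNC(=O)c2cc([N+](=O)[O-])cn2C)cc1` has not yet been measured in this assay. It differs from compound 1 by methyl in place of hydrogen on an aromatic nitrogen. Going by the values given here, no measured step touches that position; the only step available, from compound 1 to compound 3, changes a substituent on an aromatic carbon elsewhere in the molecule and moved the number hardly at all. With no evidence either way, the author expects compound 4 to behave like compound 1, that is, a step of a 1.1-fold higher number from compound 1 to compound 4 (0.02 log units; within the scatter) that stays inside the scatter. The estimate for compound 4 in this assay is therefore 350000 nM, within a range from 170000 nM to 720000 nM.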

Compound 4, half-maximal inhibitory concentration: 184000 nM
Compound 4: the middle estimate sits 1.9-fold (0.28 log units) above what was measured; the measured number falls inside the stated range.
By their numbers in this assay, from the lowest: compounds 4, 1, 2 and 3 (each within the scatter of the next, the first and the last beyond it).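

For the compounds shown here, the step at the aromatic nitrogen gives the first reading of this position in this assay, where compounds 1, 2 and 3 all carry hydrogen on that atom and the only earlier step concerned a substituent on an aromatic carbon. Methyl in place of hydrogen there gives a 1.8-fold lower number from compound 1 to compound 4 (0.26 log units; within the scatter), so this single added carbon, placed on the five-membered aromatic ring and two ring bonds from the ring atom that bears the nitro group, leaves compound 4 indistinguishable from compound 1. Nothing measured here offers an explanation for this result, and no property of either compound beyond this number is available.

The compounds shown leave open what a longer chain such as propyl, a benzyl group or a carboxylic acid on this nitrogen would do, and whether any group placed there can carry the number beyond the scatter from compound 1. They also leave open whether methyl in place of hydrogen on this nitrogen reads the same when the rest of the molecule is that of compound 2 or compound 3.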